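This account rests on a few compounds, and the source may have more. Where it says the series, first, only, none or still open, it means among the compounds named here.

Of the compounds shown here, three have been measured so far in an ADME assay on microsomes from liver (Mus musculus, strain CD1) for metabolic stability, read by HPLC, with a stated time of 30 min, tested at 1 uM; a lower number here means slower removal, a higher number faster removal of the compound. Compound 1 `Cn1cc2c(NS(=O)(=O)c3ccc(Br)cc3)cccc2n1` gives 6.3 mL.min-1.g-1, compound 2 `Cn1cc2c(NS(=O)(=O)c3ccc(Br)cc3)c(N3CCCC3)ccc2n1` gives 33 mL.min-1.g-1, and compound 3 `Cc1ccc2ncccc2c1NS(=O)(=O)c1ccc(Br)cc1` gives 3.6 mL.min-1.g-1. Compound 3 therefore sits within the usual scatter of compound 1, and both lie clearly below compound 2.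

The next compound, compound 4 `CC(C)Cc1ccc2ncccc2c1NS(=O)(=O)c1ccc(Br)cc1`, differs from compound 3 in one place: isopropyl in place of hydrogen on a saturated chain carbon bound to an aromatic carbon. In words, isopropyl stands in place of hydrogen on a saturated chain carbon bound to an aromatic carbon, so methyl becomes isobutyl.

For the measured compounds named here, only one measured step offers a guide: a 5.2-fold higher number from compound 1 to compound 2 (0.72 log units; beyond the scatter). There, pyrrolidin-1-yl replaced hydrogen on an aromatic carbon rather than on a saturated chain carbon, so the comparison is loose and rests on a single pair. It still points upward, beyond the scatter.

On that precedent, the expected change is a 3.6-fold higher number from compound 3 to compound 4 (0.56 log units; beyond the scatter), a rise of somewhat smaller size. For compound 4 the estimated value in this assay is 13 mL.min-1.g-1, with an expected range from 5 mL.min-1.g-1 to 35 mL.min-1.g-1.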

Compound 4, intrinsic clearance in microsomes: > 50 mL.min-1.g-1
Compound 4: a limit, no number; the forecaster's own chance of this, stated with the estimate: 3%; middle value at least 3.8-fold (0.58 log units) away from the limit.
By their numbers in this assay, from the lowest: compounds 3 and 1 (each within the scatter of the next); then compound 2. At a limit, above all of these: compound 4.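

The change from methyl to isobutyl gives an at least 13-fold higher number from compound 3 to compound 4 (1.14 log units; beyond the scatter) in this assay. For the compounds shown here, until now the only single change on record was on an aromatic carbon, in the core of compound 1, so this is the first sign that a saturated chain carbon bound to an aromatic carbon is also a place where a small addition can move this number strongly. Compound 4 gives a limit of the assay rather than a number, which leaves the full size of this step unread: the limit of > 50 mL.min-1.g-1 in this assay, at which 1 of the 4 values shown sits.

Only methyl and isobutyl are shown at this place, so it stays open whether an ethyl chain or an amine there would stay close to compound 3 or reach the same limit. Going by these compounds, it also stays open whether isobutyl on the core of compound 1 would give a rise of similar size.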